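Extending the aminoamino group of compound 2 to a ureido

A few compounds are considered here, and "the series" means these few. Any claim that something is new, unique, unknown or untested is made for them only; others in the source may bear on it.

Compound 1 `N#Cc1c(O)nc(SCc2nc3ccccc3[nH]2)nc1-c1ccccc1` and compound 2 `N#Cc1c(NN)nc(SCc2nc3ccccc3[nH]2)nc1-c1ccccc1` share one core and differ only at the substituent on the aromatic carbon. In a functional assay on G-361 cells (Homo sapiens) for cytotoxicity, read by MTT assay, with a stated time of 3 days (a lower number here means a stronger inhibitor, a higher number a weaker inhibitor), compound 1 gives 3.43 nM, and compound 2 gives 14.7 nM. Going by the values given here, the step of a 4.3-fold higher number from compound 1 to compound 2 (0.63 log units; beyond the scatter) leaves compound 2 with the higher of the two numbers known so far, with compound 1 as its only neighbour.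

Compound 3 `N#Cc1c(NC(N)=O)nc(SCc2nc3ccccc3[nH]2)nc1-c1ccccc1` carries the change (carbamoyl in place of amino on a nitrogen on an aromatic ring). Among the compounds with values here, no measured step touches this nitrogen; the only step, a 4.3-fold higher number from compound 1 to compound 2 (0.63 log units; beyond the scatter), concerns the replacement of hydroxy by aminoamino and does not bear on what a carbamoyl on that nitrogen does. The direction of the step in this assay is therefore open; a change no larger than the previous one is expected, with the wider range leaning toward a higher number.

For compound 3 the expected value in this assay is 22 nM, in the range 6 nM to 80 nM, which would mean a step of a 1.5-fold higher number from compound 2 to compound 3 (0.18 log units; within the scatter).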

Compound 3, half-maximal inhibitory concentration: 2.55 nM
Beside the measured number, compound 3's estimate is 8.6-fold (0.94 log units) above it; the whole stated range lies above it.
By their numbers in this assay, from the lowest: compounds 3 and 1 (each within the scatter of the next); then compound 2.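

In this assay the carbamoyl on the nitrogen gives a 5.8-fold lower number from compound 2 to compound 3 (0.76 log units; beyond the scatter), so the aminoamino group's higher number does not persist once that group is extended to ureido. Against hydroxy, ureido gives a 1.3-fold lower number from compound 1 to compound 3 (0.13 log units; within the scatter) and the step lies within the scatter, which shows that this aromatic carbon tolerates both substituents without a separable difference, while compound 2 stands apart from both compound 1 and compound 3 by steps beyond the scatter. No measurement is available that accounts for this difference.

Still open, as far as these compounds go, is whether an acetyl or a methylcarbamoyl on the same nitrogen, or a plain amine or methoxy on the aromatic carbon, would stay with compound 1 and compound 3 or with compound 2. The numbers also leave open whether this order of the three substituents holds in any other cell line.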